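Naphthyl-Pyridine Series: From Hydrazide to Acrylic Acid

The source may hold more compounds than are shown below. What is called first, only, known or untested is meant among the compounds shown, and "the series" means these compounds.

Compound 1 `NNC(=O)CCc1ccncc1-c1ccc2ccccc2c1`: 7.7 nM
Compound 2 `O=C(/C=C/c1ccncc1-c1ccc2ncccc2c1)N1CCOCC1`: 1590 nM
Compound 3 `Cn1ncc2cc(-c3cnccc3/C=C/C(=O)N3CCOCC3)ccc21`: 356 nM

In an assay on a protein complex for inhibition of CDK8/Cyclin C (Homo sapiens), with a stated time of 1 h (on this read-out lower numbers stand for stronger inhibition and higher numbers for weaker inhibition), compound 1 gives 7.7 nM, the lowest number of the three measured compounds, below compound 3 at 356 nM and compound 2 at 1590 nM. Compound 4 `O=C(O)/C=C/c1ccncc1-c1ccc2ccccc2c1` keeps the core of compound 1 and differs in one place: 2-carboxyethenyl in place of 2-(aminocarbamoyl)ethyl on an aromatic carbon. Within the data shown here, no measured pair shows this exact change, so its effect is unknown. Because compound 1 stands at 7.7 nM, a weaker result for compound 4 is expected, with a step from compound 1 to compound 4 of a 16-fold higher number from compound 1 to compound 4 (1.19 log units; beyond the scatter) in this assay. Compound 4 is therefore estimated at 120 nM, with a range from 15 nM to 900 nM.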

Compound 4, half-maximal inhibitory concentration: 5 nM
The estimate for compound 4 lay 24-fold (1.38 log units) above the measured number; measured number outside the range, below it.
By their numbers in this assay, from the lowest: compounds 4 and 1 (each within the scatter of the next); then compound 3; then compound 2.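

In this assay, 2-carboxyethenyl in place of 2-(aminocarbamoyl)ethyl on this aromatic carbon gives a 1.5-fold lower number from compound 1 to compound 4 (0.19 log units; within the scatter), so the two groups cannot be told apart by this read-out. Among these compounds, this is the first single-place comparison at this position, and it shows that the hydrazide of compound 1 is not required for a low number on this core. Nothing at hand explains why the two groups read alike. Still open, from the compounds shown here alone, is how a 2-carboxyethyl chain, a methyl ester, a morpholine amide or a longer chain would read at this place on the core of compound 1.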